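Chain length and alkoxy size in a hydroxamate series

A few compounds are considered here, and "the series" means these few. Any claim that something is new, unique, unknown or untested is made for them only; others in the source may bear on it.

Three compounds of one series were examined in a functional assay on NCI-H460 cells (Homo sapiens) for cytotoxicity; on this read-out higher numbers stand for weaker inhibition and lower numbers for stronger inhibition. Compound 1 `COc1ccc2nc(NC(=O)CCCCC(=O)NO)sc2c1` gives 21.4 ug/mL. Compound 2 `CCOc1ccc2nc(NC(=O)CCCCC(=O)NO)sc2c1` gives 7.96 ug/mL, and compound 3 `CCOc1ccc2nc(NC(=O)CCCCCCC(=O)NO)sc2c1` gives 6.58 ug/mL. The two measured steps are a 2.7-fold higher number from compound 2 to compound 1 (0.43 log units; beyond the scatter), the change being (hydrogen in place of methyl on a saturated chain carbon bound to an oxygen on an aromatic ring), and a 1.2-fold lower number from compound 2 to compound 3 (0.08 log units; within the scatter), the change being (2-(hydroxycarbamoyl)ethyl in place of hydroxycarbamoyl on a saturated chain carbon, four bonds along the chain from a carbonyl carbon).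

Compound 4 `COc1ccc2nc(NC(=O)CCCCCCC(=O)NO)sc2c1` has not yet been measured in this assay . It differs from compound 3 by hydrogen in place of methyl on a saturated chain carbon bound to an oxygen on an aromatic ring. This is the same change that turns compound 2 into compound 1, made here on the core of compound 3, which differs from the core of compound 2 by 2-(hydroxycarbamoyl)ethyl in place of hydroxycarbamoyl on a saturated chain carbon, four bonds along the chain from a carbonyl carbon; the place of the change is the same in both pairs.

For the measured compounds named here, the step from compound 3 to compound 4 is expected to be a 2.7-fold higher number from compound 3 to compound 4 (0.43 log units; beyond the scatter), resting on the single earlier example of this change, a 2.7-fold higher number from compound 2 to compound 1 (0.43 log units; beyond the scatter). Compound 4 is therefore estimated to give 17.8 ug/mL in this assay , with a likely range from 9 ug/mL to 35 ug/mL.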

Compound 4, half-maximal inhibitory concentration: 1.25 ug/mL
The estimate for compound 4 lay 14-fold (1.15 log units) above the measured number; the measured number lies below the stated range.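

In this assay, the change from ethoxy to methoxy does not carry from one core to the other: on the core of compound 3 it gives a 5.3-fold lower number from compound 3 to compound 4 (0.72 log units; beyond the scatter), opposite in direction to its effect on the core of compound 2: the same change on two cores in this assay, a 2.7-fold higher number (0.43 log units; beyond the scatter) from compound 2 to compound 1 and a 5.3-fold lower number (0.72 log units; beyond the scatter) from compound 3 to compound 4, 14-fold (1.15 log units) apart, beyond the scatter of two such steps Read the other way round, 2-(hydroxycarbamoyl)ethyl in place of hydroxycarbamoyl gives a 17-fold lower number from compound 1 to compound 4 (1.23 log units; beyond the scatter) on the methoxy compounds, far from its effect on the ethoxy compounds: the same change on two cores in this assay, a 1.2-fold lower number (0.08 log units; within the scatter) from compound 2 to compound 3 and a 17-fold lower number (1.23 log units; beyond the scatter) from compound 1 to compound 4, 14-fold (1.15 log units) apart, beyond the scatter of two such steps The two changes therefore do not add up in these four compounds, but a single pair of cores cannot show why, or which of the two outcomes is more typical of the series.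

The compounds shown leave open how a propoxy or a hydroxy group in place of the ethoxy would behave on either core, and whether a still longer chain would follow compound 4. They also leave open whether the reversal would persist with a carboxylic acid in place of the hydroxycarbamoyl group.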